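Swapping a stilbene arm for a chlorophenyl in a bile acid receptor series

A few compounds are considered here, and "the series" means these few. Any claim that something is new, unique, unknown or untested is made for them only; others in the source may bear on it.

Measured so far, in an assay on isolated protein with Bile acid receptor (Homo sapiens) as the target; a lower number here means that less compound is needed, a higher number that more compound is needed for the effect:
compound 1, `COC(=O)/C=C/c1cccc(N(Cc2ccc(/C=C/c3cccc(F)c3)cc2)C(=O)C(C)C)c1`, gives 71 nM;
compound 2, `COC(=O)/C=C/c1cccc(N(Cc2ccc(-c3cccc(Cl)c3)cc2)C(=O)C(C)C)c1`, gives 77 nM;
compound 3, `COC(=O)/C=C/c1cccc(N(Cc2ccc(/C=C/c3cccc(F)c3)cc2)C(=O)NC(C)C)c1`, gives 467 nM.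

Compound 4, `COC(=O)/C=C/c1cccc(N(Cc2ccc(-c3cccc(Cl)c3)cc2)C(=O)NC(C)C)c1`, is not yet measured. It relates to compound 3 as compound 2 relates to compound 1: the change 3-chlorophenyl in place of 2-(3-fluorophenyl)ethenyl on an aromatic carbon produced a 1.1-fold higher number from compound 1 to compound 2 (0.04 log units; within the scatter). The two cores differ by isopropylamino in place of isopropyl on a carbonyl carbon, and that change gave a 6.6-fold higher number from compound 1 to compound 3 (0.82 log units; beyond the scatter). The place of the swap is the same in both pairs, so the change from compound 3 to compound 4, (3-chlorophenyl in place of 2-(3-fluorophenyl)ethenyl on an aromatic carbon), is the same change. Because the step of a 1.1-fold higher number from compound 1 to compound 2 (0.04 log units; within the scatter) was within the scatter, the step of a 1.1-fold higher number from compound 3 to compound 4 (0.03 log units; within the scatter) is expected to be of similar size. Compound 4 is therefore estimated at 500 nM, with a likely range from 220 nM to 1200 nM.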

Compound 4, half-maximal effective concentration: 1400 nM
The estimate for compound 4 lay 2.8-fold (0.45 log units) below the measured number; the whole stated range lies below it.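

In this assay, the swap to 3-chlorophenyl gave a 3.0-fold higher number from compound 3 to compound 4 (0.48 log units; beyond the scatter), so the size of this step depends on the core that carries it: the same change on two cores in this assay, a 1.1-fold higher number (0.04 log units; within the scatter) from compound 1 to compound 2 and a 3.0-fold higher number (0.48 log units; beyond the scatter) from compound 3 to compound 4, 2.8-fold (0.44 log units) apart, beyond the scatter of two such steps

Read the other way, isopropylamino in place of isopropyl gave an 18-fold higher number from compound 2 to compound 4 (1.26 log units; beyond the scatter), and this step also depends on the group at the other end of the molecule: the same change on two cores in this assay, a 6.6-fold higher number (0.82 log units; beyond the scatter) from compound 1 to compound 3 and an 18-fold higher number (1.26 log units; beyond the scatter) from compound 2 to compound 4, 2.8-fold (0.44 log units) apart, beyond the scatter of two such steps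

Together, these four compounds show that the two changes do not act independently of each other here, but they do not show why, or how the swap would behave on any other core.

The compounds shown leave open whether this holds with a longer chain on the carbonyl carbon. They also leave open whether it holds with a carboxylic acid in place of the methyl ester.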